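Swapping a dichlorophenoxy group for a fluorophenoxy group

This account rests on a few compounds, and the source may have more. Where it says the series, first, only, none or still open, it means among the compounds named here.

Three compounds have been measured in a functional assay on 786-0 cells (Homo sapiens) for inhibition, read by sulforhodamine B assay, with a stated time of 48 h; on this read-out lower numbers stand for stronger inhibition of growth and higher numbers for weaker inhibition of growth:
- compound 1 `Nc1cc(N)c2nc(-c3ccccc3)c(Oc3ccc(Cl)c(Cl)c3)nc2c1` gives 12600 nM
- compound 2 `Nc1cc(N)c2nc(-c3ccccc3)c(NCc3ccc(Cl)c(Cl)c3)nc2c1` gives 13200 nM
- compound 3 `COc1cc(CNc2nc3cc(N)cc(N)c3nc2-c2ccccc2)cc(OC)c1OC` gives 15500 nM

Compound 1 shows the lowest of these three numbers, but its gaps to compound 2 and to compound 3 lie within the usual scatter, so no ranking among them can be claimed. The unmeasured compound 4 `Nc1cc(N)c2nc(-c3ccccc3)c(Oc3ccc(F)cc3)nc2c1` differs from compound 1 in one place: 4-fluorophenyl in place of 3,4-dichlorophenyl on an oxygen on an aromatic ring. Among the measured compounds shown here, no step between measured compounds speaks to this change, so the data give no direction for it. Compound 4 is expected to give about 18000 nM in this assay, with a range from 8000 nM to 45000 nM. The expected step of a 1.4-fold higher number from compound 1 to compound 4 (0.15 log units; within the scatter) is estimated to be small, barely beyond the scatter, toward weaker inhibition.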

Compound 4, concentration for 50% growth inhibition: 15500 nM
Compound 4: the middle estimate sits 1.2-fold (0.06 log units) above what was measured; the range from low to high includes it.
By their numbers in this assay, from the lowest: compounds 1, 2, 3 and 4 (each within the scatter of the next).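

Replacing 3,4-dichlorophenyl with 4-fluorophenyl on this oxygen in this assay gives a 1.2-fold higher number from compound 1 to compound 4 (0.09 log units; within the scatter) and leaves the two compounds indistinguishable. At this position, then, the two chlorines can give way to a single fluorine with no measurable difference in growth inhibition. Nothing available explains this result. 

Still open, on these data alone, is whether a ring carrying an amine or a carboxylic acid, or a longer chain on this oxygen, would move the number beyond the usual scatter. Whether a plain phenyl without any halogen would behave the same is also unknown.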